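Hydroxyphenyl series: outlook for compound 3

The compounds below may be only part of what the source reports. "The series", "measured", "known", "first", "only" and "open" are said of these compounds alone.

Values in a functional assay on DU-145 cells (Homo sapiens) for inhibition; on this read-out lower numbers stand for stronger inhibition and higher numbers for weaker inhibition:
Compound 1 `Oc1cccc(-c2cc(-c3cccc(F)c3)cc(-c3cccc(O)c3)n2)c1`: 23800 nM
Compound 2 `Oc1ccc(-c2cc(-c3cccc(F)c3)cc(-c3cccc(O)c3)n2)cc1`: 2700 nM

Among the measured compounds shown here, compound 2 holds the lowest of the two numbers; the one measured step, an 8.8-fold lower number from compound 1 to compound 2 (0.95 log units; beyond the scatter), concerns the hydroxyphenyl arm and not the place changed next. Compound 3 `Oc1ccc(-c2cc(-c3ccccc3C(F)(F)F)cc(-c3cccc(O)c3)n2)cc1` differs from compound 2 by 2-(trifluoromethyl)phenyl in place of 3-fluorophenyl on an aromatic carbon. For the measured compounds named here, no measured step touches this place, so the data give no direction. The expected step is a 1.3-fold higher number from compound 2 to compound 3 (0.11 log units; within the scatter), nothing beyond the scatter, with a wide range. Compound 3 is therefore estimated at 3500 nM, between 1200 nM and 12000 nM.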

Compound 3, half-maximal inhibitory concentration: 2750 nM
Compound 3: middle estimate off by 1.3-fold (0.10 log units), on the high side, and the stated range covers the measured number.
By their numbers in this assay, from the lowest: compounds 2 and 3 (each within the scatter of the next); then compound 1.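

In this assay, 2-(trifluoromethyl)phenyl in place of 3-fluorophenyl, on the aromatic carbon opposite the ring nitrogen, gives a 1.0-fold higher number from compound 2 to compound 3 (0.01 log units; within the scatter). This position therefore tolerates this change of aryl group, from 7 to 10 heavy atoms, with no shift beyond the scatter. No supporting measurement bears on this result.

Still open, going by these compounds, is whether an amine or a carboxylic acid on this aryl ring would shift the number. On these data alone, the two hydroxyphenyl arms also remain untested in combination with other groups at this position.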